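From phenylsulfonyl to methyl at the assay limit

The source may hold more compounds than are shown below. What is called first, only, known or untested is meant among the compounds shown, and "the series" means these compounds.

In a functional assay on SK-MEL-28 cells (Homo sapiens) for inhibition (a higher number here means a weaker inhibitor, a lower number a stronger inhibitor), compound 2 `O=S(=O)(c1ccccc1)n1ccc2cc(/C=C/c3ccc4ccccc4c3)ccc21` gives > 5000 nM as a limit and not a number. Compound 3 `O=S(=O)(c1ccccc1)n1ccc2cc(/C=C\c3ccc4ccccc4c3)ccc21` gives > 5000 nM as a limit too. Compound 1 `C(=C\c1ccc2ccccc2c1)\c1ccoc1` gives > 5000 nM as a limit as well. The whole picture so far is the limit of > 5000 nM in this assay, at which 3 of the 3 values shown sit, with no exact number among them.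

Compound 4 `Cn1ccc2cc(/C=C/c3ccc4ccccc4c3)ccc21` carries methyl in place of phenylsulfonyl on an aromatic nitrogen. Within the data shown here, the only measured step is a step that the two limits leave unreadable from compound 2 to compound 3 and it rests on the fact that compounds 2 and 3 differ only in the configuration as drawn with the group on the nitrogen left unchanged, so it gives no size for this swap. With no readable step to draw on, no shift beyond the scatter and no direction can be expected in this assay from these data. The expected outcome is a number no higher from compound 2 to compound 4 (the limit leaves the size open) as an estimate only. The estimated value for compound 4 is 5000 nM with an expected range from 1500 nM to 15000 nM and a good chance that the assay again reports only a limit.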

Compound 4, half-maximal inhibitory concentration: > 5000 nM
Compound 4: only a limit was reported; the forecaster's own chance of this, stated with the estimate: 70%; the middle value lies on the limit itself.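

Compound 4 gives > 5000 nM in this assay as a limit and not a number. Compound 2 also stands only at a limit, so the step between the two cannot be read. The compounds shown leave open how strong any of them really is in this assay and whether phenylsulfonyl or methyl on the aromatic nitrogen makes any difference.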